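The compounds below may be only part of what the source reports. "The series", "measured", "known", "first", "only" and "open" are said of these compounds alone.

Compound 1, `CN(C(=O)NC(=O)c1c(F)cccc1F)c1nc(C(F)(F)F)c(C(=O)N/N=C/c2cccc(C(F)(F)F)c2)s1`, gives 25.9 ug/mL in a functional assay on BCG823 cells (Homo sapiens) for inhibition, read by MTT assay, with a stated time of 72 h; on this read-out higher numbers stand for weaker inhibition and lower numbers for stronger inhibition.
Compound 2, `CN(C(=O)NC(=O)c1ccc(F)c(F)c1)c1nc(C(F)(F)F)c(C(=O)N/N=C/c2cccc(C(F)(F)F)c2)s1`, gives 4.46 ug/mL in this assay.
Compound 3, `CN(C(=O)NC(=O)c1ccccc1F)c1nc(C(F)(F)F)c(C(=O)N/N=C/c2cccc(C(F)(F)F)c2)s1`, gives 16.3 ug/mL in this assay.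

Among these three numbers, compound 3 has the second highest. Its nearest neighbour is compound 1: the step of a 1.6-fold lower number from compound 1 to compound 3 (0.20 log units; within the scatter) lies within the scatter, so the two cannot be told apart. Compound 2 is furthest away, and the step of a 3.7-fold higher number from compound 2 to compound 3 (0.56 log units; beyond the scatter) is beyond the scatter.

Compound 4, `CN(C(=O)NC(=O)c1cccc(C(F)(F)F)c1)c1nc(C(F)(F)F)c(C(=O)N/N=C/c2cccc(C(F)(F)F)c2)s1`, differs from compound 3 in one place: 3-(trifluoromethyl)phenyl in place of 2-fluorophenyl on a carbonyl carbon. Two of the measured steps bear on this change, since both alter what sits on the same ring: a 5.8-fold lower number from compound 1 to compound 2 (0.76 log units; beyond the scatter) and a 3.7-fold higher number from compound 2 to compound 3 (0.56 log units; beyond the scatter). Both are modest, and both favour the ring carrying its fluorines away from the pattern of compound 3. Among the measured compounds shown here, no measured step, however, brings a trifluoromethyl onto this ring, so the expectation here is loose. A modest step to a lower number in this assay is expected, a 2.0-fold lower number from compound 3 to compound 4 (0.31 log units; beyond the scatter). Compound 4 is therefore estimated at 8 ug/mL, with a range from 3 ug/mL to 25 ug/mL.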

Compound 4, half-maximal inhibitory concentration: 4.6 ug/mL
Compound 4: the middle estimate sits 1.7-fold (0.24 log units) above what was measured; the measured number falls inside the stated range.
By their numbers in this assay, from the lowest: compounds 2 and 4 (each within the scatter of the next); then compounds 3 and 1 (each within the scatter of the next).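

The carbonyl carbon accepts a ring without a fluoro substituent: 3-(trifluoromethyl)phenyl in place of 2-fluorophenyl gives a 3.5-fold lower number from compound 3 to compound 4 (0.55 log units; beyond the scatter) in this assay, and in place of 2,6-difluorophenyl it gives a 5.6-fold lower number from compound 1 to compound 4 (0.75 log units; beyond the scatter) on the same read-out. Against 3,4-difluorophenyl the change gives a 1.0-fold higher number from compound 2 to compound 4 (0.01 log units; within the scatter) and the two cannot be told apart, so two differently substituted rings land at the same level, and the four compounds fall into a lower pair, compounds 2 and 4, and a higher pair, compounds 1 and 3. Nothing measured here accounts for this split.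

On these data alone, how this ring would behave with a methoxy group, an amine or a carboxylic acid in place of its fluoro or trifluoromethyl groups remains open. So does the effect of 2-(trifluoromethyl)phenyl at this carbonyl carbon.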